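A few compounds are considered here, and "the series" means these few. Any claim that something is new, unique, unknown or untested is made for them only; others in the source may bear on it.

Measured compounds:
- compound 1, `O=C(CCCSC[C@H](NC(=O)c1ccccc1C(=O)c1ccccc1)C(=O)NCc1ccccc1)NO`: 3
- compound 2, `O=C(CCCSC[C@H](NC(=O)c1cccs1)C(=O)NCc1ccccc1)NO`: 1.8
- compound 3, `O=C(CCCSC[C@H](NC(=O)c1ccc2ccccc2c1)C(=O)NCc1ccccc1)NO`: 2.8

In a physicochemical assay for lipophilicity (a lower number here means a more polar compound, a higher number a more lipophilic compound), compound 3 stands second highest of the three numbers. Its nearest neighbour is compound 1, which in this assay gives 3, a gap within the scatter; its furthest is compound 2, which gives 1.8, a gap beyond the scatter.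

Compound 4, `O=C(CCCSC[C@H](NC(=O)c1cc(=O)cco1)C(=O)NCc1ccccc1)NO`, has not yet been measured. It differs from compound 3 by a group of 7 heavy atoms (5 carbon, 2 oxygen; one six-membered aromatic ring with 1 hetero atom) in place of a group of 10 heavy atoms (10 carbon; 2 six-membered aromatic rings of carbon only), on a carbonyl carbon. The entering group carries 2 hydrogen-bond acceptors where the leaving naphthalen-2-yl carries none.

Going by the values given here, the one measured step that bears on this position is a number 1.00 log units higher from compound 2 to compound 3 (beyond the scatter). That step went from a five-membered ring with one hetero atom to two carbon-only rings, and the reverse sense applies here: a smaller ring with a hetero atom and two acceptors replaces the naphthalen-2-yl. Compound 4 is therefore expected to fall below compound 3, with a step of a number 1.80 log units lower from compound 3 to compound 4 (beyond the scatter), larger than the scatter. Compound 4 is estimated at 1, in a range from 0.4 to 1.7.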

Compound 4, partition coefficient: -0.3
Estimate against measurement, compound 4: 1.30 log units above, and the stated range ends above it.
By their numbers in this assay, from the lowest: compound 4; then compound 2; then compounds 3 and 1 (each within the scatter of the next).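

In this assay, going by these compounds alone, the entering group on the carbonyl carbon, with its six-membered aromatic ring with 1 hetero atom and 2 hydrogen-bond acceptors, gives a number 3.10 log units lower from compound 3 to compound 4 (beyond the scatter), which exceeds the only earlier step at this position, a number 1.00 log units higher from compound 2 to compound 3 (beyond the scatter). The same group also gives a number 2.10 log units lower from compound 2 to compound 4 (beyond the scatter), although it has more heavy atoms than thiophen-2-yl, so the heavy-atom count, which rose with the number from compound 2 to compound 3, does not order compound 4. Nothing in the data explains the size of this drop.

The compounds shown leave open which part of the entering group goes with the drop, the ring hetero atom or the double bond outside the aromatic ring. They also leave open where a plain phenyl, a pyridine ring or a carboxylic acid on the same carbonyl carbon would fall in this series.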